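A few compounds are considered here, and "the series" means these few. Any claim that something is new, unique, unknown or untested is made for them only; others in the source may bear on it.

Compound 1, `Cc1nnc(SCc2cc(=O)c3ccccc3o2)s1`: > 25000 nM
Compound 2, `Cc1nnc(SCc2cc(=O)c3cc(Cl)ccc3o2)o1`: > 25000 nM

In a functional assay on SW480 cells (Homo sapiens) for cytotoxicity, read by MTT assay, with a stated time of 72 h (a lower number here means a stronger inhibitor, a higher number a weaker inhibitor), compound 1 is reported only as a limit, > 25000 nM. Compound 2 likewise yields only a limit in this assay, namely > 25000 nM. Among the compounds with values here, both readings sit at the same place, (the limit of > 25000 nM in this assay, at which 2 of the 2 values shown sit), so compound 2 stands exactly where the only other measured compound stands, and no step between measured compounds can be sized from these two entries.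

Compound 3, `Cc1nnc(SCc2cc(=O)c3ccccc3o2)o1`, differs from compound 2 by hydrogen in place of chloro on an aromatic carbon. Within the data shown here, with no measured step available and both measured compounds resting at the assay limit, the step expected in this assay from compound 2 to compound 3 is none beyond the scatter, and compound 3 is expected most likely to be returned as a limit as well. The estimate for compound 3 in this assay is 40000 nM, with a range from 20000 nM to 120000 nM. That estimate corresponds to an expected change of a step that the limit leaves unreadable from compound 2 to compound 3.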

Compound 3, half-maximal inhibitory concentration: > 25000 nM
Compound 3 ended at the assay's limit; the forecaster's own chance of this, stated with the estimate: 85%; the middle value lies beyond the limit too.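

Neither the step from compound 2 to compound 3 nor the step from compound 1 to compound 3 can be read in this assay, because all three compounds give the same limit: the limit of > 25000 nM in this assay, at which 3 of the 3 values shown sit.

The compounds shown leave open whether chloro or hydrogen on the aromatic carbon, or 5-methyl-1,3,4-oxadiazol-2-yl or 5-methyl-1,3,4-thiadiazol-2-yl on the sulfur, makes any difference in this assay.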